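Compound 4: butylamino in place of propoxy

The source may report more compounds than this note shows. Statements on the series, on what has been measured and on what is new or still open speak of the compounds shown alone.

Compound 1 `Nc1nc(OCC(F)(F)F)c2ncn(/C=C3/CC3(CO)CO)c2n1` gives > 300000 nM as a limit
Compound 2 `Nc1nc(NCc2ccccc2)c2ncn(/C=C3/CC3(CO)CO)c2n1` gives > 300000 nM as a limit
Compound 3 `CCCOc1nc(N)nc2c1ncn2/C=C1/CC1(CO)CO` gives > 300000 nM as a limit

All three results come from an ADME assay on HFF cells (Homo sapiens) for cytotoxicity, with a stated time of 8 days (a lower number here means that less compound is tolerated, a higher number that more compound is tolerated), and none is a number. Compound 3 stands at the limit of > 300000 nM in this assay, at which 3 of the 3 values shown sit, and so has no exact place among the others.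

Compound 4 `CCCCNc1nc(N)nc2c1ncn2/C=C1/CC1(CO)CO` follows from compound 3 with one change: butylamino in place of propoxy on an aromatic carbon. Butylamino enters in place of propoxy, on an aromatic carbon next to the ring nitrogen.

The closest measured change is a step that the two limits leave unreadable from compound 2 to compound 3, which also swaps propoxy and an amino group at this place. The other two, a step that the two limits leave unreadable from compound 1 to compound 2 and a step that the two limits leave unreadable from compound 1 to compound 3, give no size either. Compound 2, with benzylamino at this place, is also a limit (> 300000 nM). A step beyond the scatter is therefore not expected, and no direction can be argued. The expected change is a number no higher from compound 3 to compound 4 (the limit leaves the size open) in this assay, most likely hidden behind a limit again. Compound 4 is estimated at 300000 nM with an expected range of 100000 nM to 600000 nM as its span.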

Compound 4, half-maximal cytotoxic concentration: > 300000 nM
Compound 4 ended at the assay's limit; the forecaster's own chance of this, stated with the estimate: 80%; the middle value lies on the limit itself.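

In this assay compound 4 gives > 300000 nM as a limit of the assay and not a number. Going by these compounds alone, no new step to compound 4 from compound 1, compound 2 or compound 3 can be read. The compounds shown leave open how these groups rank in tolerated concentration: the limit of > 300000 nM in this assay, at which 4 of the 4 values shown sit.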